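The source may hold more compounds than are shown below. What is called first, only, known or untested is meant among the compounds shown, and "the series" means these compounds.

Three compounds share one core that carries a 3-hydroxyphenyl group, a thiophen-3-yl group and a chlorophenyl group, and they differ only in which chlorophenyl group is present. Compound 1 `Oc1cccc(-c2cc(-c3ccc(Cl)cc3)nc(-c3ccsc3)c2)c1` carries a 4-chlorophenyl group; in an assay on isolated protein for inhibition of DNA topoisomerase 1 (Homo sapiens), with a stated time of 30 min, tested at 100 uM (a lower number here means a weaker effect, a higher number a stronger effect of the compound at the concentration tested), compound 1 gives 11.7%. Compound 2 `Oc1cccc(-c2cc(-c3ccsc3)nc(-c3cccc(Cl)c3)c2)c1` carries a 3-chlorophenyl group, and compound 2 gives 26.2%, the highest of the three numbers. Compound 3 `Oc1cccc(-c2cc(-c3ccsc3)nc(-c3ccccc3Cl)c2)c1` carries a 2-chlorophenyl group, and compound 3 gives 0%. The measured steps are a number 14.5 percentage points higher from compound 1 to compound 2 (beyond the scatter), a number 11.7 percentage points lower from compound 1 to compound 3 (beyond the scatter) and a number 26.2 percentage points lower from compound 2 to compound 3 (beyond the scatter), each modest and each concerned only with the chlorophenyl group.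

Compound 4 `Oc1cccc(-c2cc(-c3ccccc3)nc(-c3cccc(Cl)c3)c2)c1` keeps the 3-chlorophenyl group of compound 2 and changes a different part of the molecule: phenyl in place of thiophen-3-yl on an aromatic carbon. Going by the values given here, none of the measured steps touches this part, so they offer no direct guide to its size or direction. The expectation is therefore a step of a number 2.2 percentage points lower from compound 2 to compound 4 (within the scatter), which stays within the usual scatter. Compound 4 is thus estimated at 24%, with a range from 5% to 42%.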

Compound 4, a percentage reported as inhibition, at one concentration (the size of the read-out at that concentration, not a potency): 11.5%
Compound 4: the middle estimate sits 12.5 percentage points above what was measured, and the stated range covers the measured number.
By their numbers in this assay, from the lowest: compound 3; then compounds 4 and 1 (each within the scatter of the next); then compound 2.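

Putting phenyl in place of thiophen-3-yl, on the aromatic carbon next to the ring nitrogen, gives a number 14.7 percentage points lower from compound 2 to compound 4 (beyond the scatter) in this assay. Going by these compounds alone, the read-out therefore depends on this position as well as on the chlorophenyl group, the only part that varied among the earlier compounds. This single swap changes both ring size and the presence of sulfur, so it cannot show which of the two matters, and no supporting evidence is available to explain the step.

The compounds shown leave open how a furan-3-yl group, a thiophen-2-yl group or an amine would read at this position. As far as these compounds go, it is also open whether the same swap would give a similar step alongside the 4-chlorophenyl group of compound 1 or the 2-chlorophenyl group of compound 3.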